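Acetoxy on the chain carbon of the prenyl-bearing quinone core

The compounds below may be only part of what the source reports. "The series", "measured", "known", "first", "only" and "open" are said of these compounds alone.

Two compounds of the series have been run in a functional assay on PC-3 cells (Homo sapiens) for cytotoxicity, read by MTT assay, with a stated time of 48 h; on this read-out higher numbers stand for weaker inhibition and lower numbers for stronger inhibition. Compound 1 `COc1ccc(O)c2c1C(=O)C=C(CCC=C(C)C)C2=O` gives 6810 nM in this assay. Its isomer, compound 2 `COc1ccc(O)c2c1C(=O)C(CCC=C(C)C)=CC2=O`, in which the chain sits on the other carbon of the same ring, gives 7480 nM in this assay. The two numbers lie within the usual scatter of one another, so the data place compound 1 and compound 2 together and give no order between them.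

Compound 3 `COc1ccc(O)c2c1C(=O)C=C([C@H](CC=C(C)C)OC(C)=O)C2=O` is still to be measured in this assay. Relative to compound 1 it carries acetoxy in place of hydrogen on a saturated chain carbon bound to a double-bonded ring carbon and a saturated chain carbon. Within the data shown here, no pair of measured compounds differing in just this way is available, so the size and direction of the step cannot be read from a precedent; the only anchor is the value of compound 1 in this assay, 6810 nM.

With that anchor, the expectation for compound 3 is a step of a 1.1-fold lower number from compound 1 to compound 3 (0.05 log units; within the scatter) that stays within the scatter. The estimated value for compound 3 in this assay is 6000 nM, with a range from 2500 nM to 15000 nM.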

Compound 3, half-maximal inhibitory concentration: 780 nM
Compound 3: the middle estimate sits 7.7-fold (0.89 log units) above what was measured; measured number below the stated range.
By their numbers in this assay, from the lowest: compound 3; then compounds 1 and 2 (each within the scatter of the next).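

Acetoxy in place of hydrogen on a saturated chain carbon bound to a double-bonded ring carbon and a saturated chain carbon gives an 8.7-fold lower number from compound 1 to compound 3 (0.94 log units; beyond the scatter) in this assay. This chain carbon is thus a place where a single change moves the read-out beyond the scatter, which the earlier pair could not show, since moving the chain to the other carbon of the same ring left compound 1 and compound 2 together. Nothing at hand accounts for the size or direction of this step.

On these data alone, it remains open whether the whole acetoxy group is required at this carbon or whether a smaller or larger replacement, such as a hydroxy group or a longer butyryloxy group, would give a similar number. Also open, as far as these compounds go, is whether acetoxy on the corresponding chain carbon of compound 2 would give a step of similar size, and whether the opposite configuration at this carbon would match compound 3.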